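Swapping 4-methylbenzyl for 3-methylphenyl: expected effect on growth inhibition

The source may hold more compounds than are shown below. What is called first, only, known or untested is meant among the compounds shown, and "the series" means these compounds.

In a functional assay on MCF7 cells (Homo sapiens) for inhibition, read by CCK-8 assay, with a stated time of 48 h (a higher number here means a weaker inhibitor of growth, a lower number a stronger inhibitor of growth), compound 1 `CCN1CCN(c2ccc(Nc3ncc(Cl)c(Nc4ccccc4C)n3)cc2)CC1` gives 3160 nM and compound 2 `Cc1ccc(CNc2nc(Nc3ccc(N4CCN(C)CC4)cn3)ncc2Cl)cc1` gives 38100 nM, the higher of the two numbers and beyond the scatter. Compound 3 `Cc1cccc(Nc2nc(Nc3ccc(N4CCN(C)CC4)cn3)ncc2Cl)c1` has 3-methylphenyl in place of 4-methylbenzyl on a nitrogen on an aromatic ring. Among the measured compounds shown here, no measured pair isolates this change. Compound 1 at 3160 nM also lacks 4-methylbenzyl but differs elsewhere too, so it is only a weak guide. A move to a lower number in this assay is expected, with an estimated step of a 3.8-fold lower number from compound 2 to compound 3 (0.58 log units; beyond the scatter). For compound 3 the estimated value is 10000 nM, with an expected range of 3000 nM to 30000 nM.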

Compound 3, concentration for 50% growth inhibition: 7160 nM
Compound 3: the middle estimate sits 1.4-fold (0.15 log units) above what was measured; the measured number falls inside the stated range.
By their numbers in this assay, from the lowest: compound 1; then compound 3; then compound 2.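

In this assay, among the compounds shown here, the exchange of 4-methylbenzyl for 3-methylphenyl on a nitrogen on an aromatic ring gives a 5.3-fold lower number from compound 2 to compound 3 (0.73 log units; beyond the scatter) and is the first measured step at this position. The position is therefore sensitive to this change, with a six-membered aromatic ring of carbon only present on both sides of the step. No measured property bears on the step, so it remains without an assigned cause.

The step joins two changes, the loss of the benzyl carbon and the shift of the methyl, and the compounds shown do not separate them. Also open, as far as these compounds go, is how 4-methylphenyl, 3-methylbenzyl or an amine-bearing phenyl would read at this nitrogen.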